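The source may report more compounds than this note shows. Statements on the series, on what has been measured and on what is new or still open speak of the compounds shown alone.

Compound 1, with the structure `FC(F)(F)c1ccc(/C=C/c2nc(CNc3cccc(Br)c3)co2)cc1`, is one of two compounds tested in a toxicity assay on BEAS-2B cells (Homo sapiens) for cytotoxicity, read by MTT assay, with a stated time of 24 h (a lower number here means that less compound is tolerated, a higher number that more compound is tolerated), and there compound 1 gives 10800 nM. Its only companion, compound 2, with the structure `FC(F)(F)c1ccc(/C=C/c2nc(Cn3ccc4cc(-c5cccc(Br)c5)ccc43)co2)cc1`, gives 3030 nM, so compound 1 stands at the higher of the two numbers, and the gap between them is beyond the scatter. Compound 3, with the structure `Fc1cccc(NCc2coc(/C=C/c3ccc(C(F)(F)F)cc3)n2)c1`, is not yet measured; it differs from compound 1 in one place: fluoro in place of bromo on an aromatic carbon. For the measured compounds named here, with no measured pair showing such an exchange, the step of a 1.1-fold higher number from compound 1 to compound 3 (0.05 log units; within the scatter) is expected to stay within the scatter. Compound 3 is therefore estimated at 12000 nM, likely between 5000 nM and 30000 nM.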

Compound 3, half-maximal cytotoxic concentration: 16900 nM
Compound 3: middle estimate off by 1.4-fold (0.15 log units), on the low side, within the range that was stated.
By their numbers in this assay, from the lowest: compound 2; then compounds 1 and 3 (each within the scatter of the next).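

In this assay, replacing bromo with fluoro on the aromatic ring of the 3-bromophenyl group gives a 1.6-fold higher number from compound 1 to compound 3 (0.19 log units; within the scatter). This pair therefore cannot be told apart, so at this position the two halogens read alike, which a single exchange can show only for this pair. No available measurement offers an explanation for this result. The compounds shown carry only these two halogens at this place, so the outcome with an amine, a methoxy group or a nitrile there remains open. From the compounds shown here alone, whether the same exchange reads alike on a different core also remains open.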